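The source may report more compounds than this note shows. Statements on the series, on what has been measured and on what is new or still open speak of the compounds shown alone.

Compound 1 `COc1cc(Cl)cc(-c2nn(-c3cccc(NC(=O)Nc4ccc(Cl)c(C(F)(F)F)c4)c3)cc2-c2ccncc2)c1` is one of three close analogues that share one core and a urea-linked outer ring, differing only in the substitution of that outer ring. In a functional assay on UACC-257 cells (Homo sapiens) for inhibition, read by sulforhodamine B assay, with a stated time of 48 h, tested at 100 uM (a higher number here means a weaker effect of the compound at the concentration tested, a lower number a stronger effect), compound 1 gives -86%. Compound 2 `COc1cc(Cl)cc(-c2nn(-c3cccc(NC(=O)Nc4cc(C(F)(F)F)cc(C(F)(F)F)c4)c3)cc2-c2ccncc2)c1` gives -88% in this assay, a number that lies within the scatter of the value of compound 1, so the two cannot be told apart. Compound 3 `COc1cc(Cl)cc(-c2nn(-c3cccc(NC(=O)Nc4ccc(Cl)c(Cl)c4)c3)cc2-c2ccncc2)c1` gives -36%, and the step of a number 50 percentage points higher from compound 1 to compound 3 (beyond the scatter) is the one large movement among the three.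

Compound 4 `COc1cc(Cl)cc(-c2nn(-c3cccc(NC(=O)Nc4cccc(C(F)(F)F)c4)c3)cc2-c2ccncc2)c1` has not been measured in this assay. It differs from compound 1 by hydrogen in place of chloro on an aromatic carbon; the trifluoromethyl group of compound 1 is kept. Going by the values given here, no measured step shows the removal of this chloro directly. Among the compounds with values here, the only step that touches the same ring, the one from compound 1 to compound 3, exchanged the trifluoromethyl instead, so it gives no more than a warning that this ring is sensitive to change. Compound 4 is therefore expected to give a number not far from that of compound 1, with a wide range allowed. Compound 4 is estimated at -70% in this assay, between -95% and -35%, an expected step of a number 16 percentage points higher from compound 1 to compound 4 (beyond the scatter).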

Compound 4, a percentage reported as activity, at one concentration (the size of the read-out at that concentration, not a potency): -72%
Compound 4: the middle estimate sits 2 percentage points above what was measured; low and high end bracket the measured number.
By their numbers in this assay, from the lowest: compounds 2 and 1 (each within the scatter of the next); then compound 4; then compound 3.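

In this assay, hydrogen in place of chloro ortho to the trifluoromethyl group gives a number 14 percentage points higher from compound 1 to compound 4 (beyond the scatter), and hydrogen in place of the second trifluoromethyl group gives a number 16 percentage points higher from compound 2 to compound 4 (beyond the scatter), so among these compounds a second group on the outer ring adds only a modest part of the effect when one trifluoromethyl group is present. The change to 3-(trifluoromethyl)phenyl from 3,4-dichlorophenyl gives a number 36 percentage points lower from compound 3 to compound 4 (beyond the scatter), so the ring with a lone trifluoromethyl group and no chloro keeps far more of the effect than the ring with two chloro groups. Nothing measured here explains why these steps differ in size.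

The compounds shown leave open how a fluoro, a nitrile or an amine would behave on the carbon that held the chloro. Going by these compounds alone, they also leave open whether the ring needs the trifluoromethyl group at all, since no compound here has a chloro alone on it.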